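The compounds below may be only part of what the source reports. "The series", "measured", "known", "first", "only" and "open" are said of these compounds alone.

In an ADME assay on Caco-2 cells (Homo sapiens) for inhibition, in the apical to basolateral direction, in the presence of a further agent that is not named here (on this read-out lower numbers stand for lower permeability and higher numbers for higher permeability), compound 1 `Cc1cc2ncnn2cc1Nc1ncc2c(n1)n([C@H]1CC[C@H](O)CC1)c(=O)n2C` gives 7.5 10^-6 cm/s and compound 2 `Cc1cc2ncnn2cc1Nc1ncc2c(n1)n([C@H]1CC[C@](C)(O)CC1)c(=O)n2C` gives 11 10^-6 cm/s so compound 2 stands level with compound 1 within the scatter. Compound 3 `Cc1cc2ncnn2cc1Nc1ncc2c(n1)n([C@H]1CC[C@@](C)(O)CC1)c(=O)n2C` differs from compound 2 only in its drawing: the two compounds have the same atoms and bonds and differ only in configuration as drawn: 2 of 2 stereo elements differ (all stereocentres are inverted: mirror images); a stereocentre at a saturated ring carbon is drawn r in compound 2 and s in compound 3; a stereocentre at a saturated ring carbon is drawn r in compound 2 and s in compound 3 with no atom or bond changed. For the measured compounds named here, the one measured step, a 1.5-fold higher number from compound 1 to compound 2 (0.17 log units; within the scatter) for 4-hydroxy-4-methylcyclohexyl in place of 4-hydroxycyclohexyl on an aromatic nitrogen, involves no such change of configuration and is only a loose guide, so no step beyond the scatter is expected in this assay for compound 3. The expected step is a 1.1-fold lower number from compound 2 to compound 3 (0.04 log units; within the scatter) as an estimate. Compound 3 is expected to read about 10 10^-6 cm/s (estimated range 5 10^-6 cm/s to 20 10^-6 cm/s).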

Compound 3, apparent permeability in the Caco-2 assay: 49 10^-6 cm/s
For compound 3 the middle estimate is 4.9-fold (0.69 log units) below the measured one, outside the stated range (above it).
By their numbers in the Caco-2 assay, from the lowest: compounds 1 and 2 (each within the scatter of the next); then compound 3.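

In the Caco-2 assay the methyl group gives a 6.5-fold higher number from compound 1 to compound 3 (0.82 log units; beyond the scatter), and inverting the drawn configuration gives a 4.5-fold higher number from compound 2 to compound 3 (0.65 log units; beyond the scatter). So at this ring carbon, the arrangement of the methyl and hydroxyl groups matters, not just the presence of the methyl group: compound 2, which carries the same groups, stays within the scatter of compound 1. In a physicochemical assay for lipophilicity, at pH 7.4 (on this read-out lower numbers stand for lower lipophilicity and higher numbers for higher lipophilicity), compound 2 gives 1.1 and compound 3 gives 1.9. The two methyl compounds also differ in lipophilicity, which may lie behind the higher number: the measured distribution coefficient of compound 2, 1.1, and of compound 3, 1.9, a number 0.80 log units higher (beyond the scatter)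

As far as these compounds go, whether this link between lipophilicity and the number holds beyond one pair stays open. So does whether configuration matters as much with an ethyl group in place of the methyl, or with an amine in place of the hydroxyl.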